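The source may report more compounds than this note shows. Statements on the series, on what has been measured and on what is new or still open speak of the compounds shown alone.

Measured compounds:
compound 1 `COc1ccc(CNc2nc(NCc3ccc(OC)cc3)c3ccccc3n2)cc1` gives 3870 nM in a functional assay on T-24 cells (Homo sapiens) for cytotoxicity, read by neutral red uptake, with a stated time of 72 h; on this read-out lower numbers stand for stronger inhibition and higher numbers for weaker inhibition;
compound 2 `CCNc1nc(SCC)nc2ncccc12` gives 20100 nM in this assay;
compound 3 `c1ccc(CCCNc2nc(NCCCc3ccccc3)c3cccnc3n2)cc1` gives 13200 nM in this assay.

Among these three, compound 2 carries the highest number in this assay. Its neighbour on the scale is compound 3, whose number sits within the usual scatter of compound 2, so the two cannot be told apart. Compound 1 lies beyond the scatter from compound 2 and stands clearly apart from it.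

Compound 4 `CCCCCCNc1nc(SCC)nc2ncccc12` has not yet been measured. It differs from compound 2 in one place: butyl in place of hydrogen on a saturated chain carbon, two bonds along the chain from a nitrogen on an aromatic ring. Within the data shown here, no pair of measured compounds here differs in exactly one place, so no measured step can be set beside this change. The other two measured compounds carry other cores and other substituents and give no direct guide.

With that, compound 4 is expected to stay near compound 2, with a step of a 1.7-fold lower number from compound 2 to compound 4 (0.22 log units; within the scatter) that is estimated to be small and, if anything, toward a lower number. Compound 4 is therefore estimated at 12000 nM, within a range from 4000 nM to 40000 nM.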

Compound 4, half-maximal inhibitory concentration: 5900 nM
Compound 4: middle estimate off by 2.0-fold (0.31 log units), on the high side; the measured number falls inside the stated range.
By their numbers in this assay, from the lowest: compounds 1 and 4 (each within the scatter of the next); then compounds 3 and 2 (each within the scatter of the next).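

Read in this assay, the change from ethyl to hexyl, which is butyl in place of hydrogen on a saturated chain carbon, gives the first step in this set between two compounds that differ in one place (a 3.4-fold lower number from compound 2 to compound 4 (0.53 log units; beyond the scatter)). The step lies beyond the scatter, so this position is not indifferent to chain length: on the shared core, the longer chain goes with the lower number. No measurement shown gives a reason for this step.

The compounds shown leave open whether the number would keep falling with a longer chain such as octyl, or would change with an amine or a carboxylic acid at the chain end. One step also cannot tell whether the same change would act alike on another core.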